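The compounds below may be only part of what the source reports. "The series", "measured", "known", "first", "only" and "open" are said of these compounds alone.

Compound 3 `O=C(O)c1cccc(OCc2ccc(OCc3c(-c4c(Cl)cccc4Cl)noc3C3CC3)nc2C(F)(F)F)c1` in a functional assay on HEK293 cells for agonist activity at Bile acid receptor (Homo sapiens), read by a luciferase reporter (a higher number here means a larger maximal response, a lower number a smaller maximal response), gives 41%. Among the three measured compounds it holds the second highest number. Compound 2 `O=C(O)c1ccccc1OCc1ccc(OCc2c(-c3c(Cl)cccc3Cl)noc2C2CC2)nc1C(F)(F)F` gives 33%, and the step of a number 8 percentage points higher from compound 2 to compound 3 (within the scatter) lies within the scatter. Compound 1 `CN(Cc1ccc(C(=O)O)cc1)c1ccc(OCc2c(-c3c(Cl)cccc3Cl)noc2C2CC2)nc1C(F)(F)F` gives 60%, and the step of a number 19 percentage points lower from compound 1 to compound 3 (beyond the scatter) lies beyond it, as does the step of a number 27 percentage points lower from compound 1 to compound 2 (beyond the scatter). Compound 4 `O=C(O)c1ccc(OCc2ccc(OCc3c(-c4c(Cl)cccc4Cl)noc3C3CC3)nc2C(F)(F)F)cc1` is the next to be measured. Its change from compound 3 is 4-carboxyphenyl in place of 3-carboxyphenyl on an oxygen on a saturated carbon. Within the data shown here, the one earlier step at the same place is the step of a number 8 percentage points higher from compound 2 to compound 3 (within the scatter), which stayed within the scatter; the two larger steps touch a different part of the molecule and do not speak to this change. It is therefore expected that the step of a number 1 percentage points higher from compound 3 to compound 4 (within the scatter) stays within the scatter, in no clear direction. Compound 4 is estimated to give 42% in this assay, with a range from 30% to 55%.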

Compound 4, largest response reached (reported as efficacy), in percent of the reference or control that the assay uses: 42%
For compound 4 middle estimate and measured number coincide at the digits printed; the range from low to high includes it.
By their numbers in this assay, from the lowest: compounds 2, 3 and 4 (each within the scatter of the next); then compound 1.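

In this assay, the series on this oxygen now has all three placements of the carboxyl group: the result is a number 1 percentage points higher from compound 3 to compound 4 (within the scatter), and a number 9 percentage points higher from compound 2 to compound 4 (within the scatter). The 2-carboxyphenyl, 3-carboxyphenyl and 4-carboxyphenyl groups therefore cannot be told apart at this position in this read-out. The gap to the amine-linked compound also remains when both compounds carry the carboxyl group as a 4-carboxy substituent, with a number 18 percentage points lower from compound 1 to compound 4 (beyond the scatter), so the placement of the carboxyl group alone does not account for it.

Going by these compounds, it remains open whether a (4-carboxyphenyl)amino or a longer chain in place of the (4-carboxyphenoxy)methyl group would change the response, or a tetrazole in place of the carboxylic acid. Nothing measured here explains these numbers.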